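Aryl versus alkyl on the ring nitrogen: compound 4

This account rests on a few compounds, and the source may have more. Where it says the series, first, only, none or still open, it means among the compounds named here.

Measured so far:
compound 1, `Nc1ccccc1NC(=O)c1ccc(CSC(=S)N2CCN(C3CCCCC3)CC2)cc1`: 76.1%
compound 2, `COc1ccc(N2CCN(C(=S)SCc3ccc(C(=O)Nc4ccccc4N)cc3)CC2)cc1`: 52.3%
compound 3, `CN1CCN(C(=S)SCc2ccc(C(=O)Nc3ccccc3N)cc2)CC1`: 75.7%

Three compounds were tested in a functional assay on HeLa cells (Homo sapiens) for antiproliferative activity, read by CCK-8 assay, with a stated time of 72 h, tested at 8 uM; on this read-out lower numbers stand for a weaker effect and higher numbers for a stronger effect at the one concentration tested. Compound 3 stands second highest of the three numbers; its nearest neighbour is compound 1, whose value sits within the scatter of it, and its furthest is compound 2, which lies beyond the scatter below it.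

Compound 4 is `Nc1ccccc1NC(=O)c1ccc(CSC(=S)N2CCN(c3ccccc3)CC2)cc1`. It differs from compound 3 by phenyl in place of methyl on an amine nitrogen in a ring. Going by the values given here, two measured steps bear on this change, both of which swap an alkyl group for an aromatic ring, or the reverse, on the same ring nitrogen: a number 23.8 percentage points lower from compound 1 to compound 2 (beyond the scatter) and a number 23.4 percentage points higher from compound 2 to compound 3 (beyond the scatter). In both, the compound carrying the aromatic ring gives the lower number, by a modest amount beyond the scatter. Phenyl, like 4-methoxyphenyl, is an aromatic ring entering at this position, so a modest drop is expected, though a plain phenyl need not behave exactly as 4-methoxyphenyl did.

The expected step is a number 17.7 percentage points lower from compound 3 to compound 4 (beyond the scatter). Compound 4 is therefore estimated at 58%, in a range from 42% to 74%.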

Compound 4, a percentage reported as inhibition, at one concentration (the size of the read-out at that concentration, not a potency): 73.1%
Compound 4: middle estimate off by 15.1 percentage points, on the low side, within the range that was stated.
By their numbers in this assay, from the lowest: compound 2; then compounds 4, 3 and 1 (each within the scatter of the next).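

In this assay, an aromatic ring on the ring nitrogen does not by itself set a compound apart, as shown by a number 2.6 percentage points lower from compound 3 to compound 4 (within the scatter) and a number 3 percentage points lower from compound 1 to compound 4 (within the scatter); methyl, cyclohexyl and phenyl at this position all give numbers within the scatter of one another. The lower number of compound 2 is instead tied to the methoxy group on its aromatic ring, since replacing that group with hydrogen gives a number 20.8 percentage points higher from compound 2 to compound 4 (beyond the scatter), and compound 2 is the only one of the four that breaks the otherwise flat picture at this position. Nothing measured here explains why the methoxy group has this effect on the number.

The compounds shown leave open whether the fall is particular to methoxy or would also follow from another group on the phenyl ring, such as a fluorine, a hydroxyl or an amine. Since this assay reports one concentration, it also leaves open whether compounds 1, 3 and 4, which cannot be told apart at that concentration, would show a stronger or weaker effect than one another at other concentrations.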